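Trimming a Dialkylamino Group to a Cyclobutylamino Group

The source may hold more compounds than are shown below. What is called first, only, known or untested is meant among the compounds shown, and "the series" means these compounds.

Compound 1 `CCCN(C)c1nc(C)nc2c(-c3c(C)cc(OC)cc3OC)c(C)nn12` and compound 2 `CCCN(c1nc(C)nc2c(-c3c(C)cc(OC)cc3OC)c(C)nn12)C1CC1` share one core and differ only on a ring nitrogen. In an assay on cell membranes for displacement of a labelled ligand from corticotropin-releasing factor receptor 1 (Rattus norvegicus) (a higher number here means a weaker inhibitor, a lower number a stronger inhibitor), compound 1 gives 6.48 nM, while compound 2 gives 1.48 nM, the lowest of the two numbers; that change was a 4.4-fold lower number from compound 1 to compound 2 (0.64 log units; beyond the scatter). Compound 3 `COc1cc(C)c(-c2c(C)nn3c(NC4CCC4)nc(C)nc23)c(OC)c1` brings a larger change: cyclobutylamino in place of cyclopropyl(propyl)amino on an aromatic carbon. Among the compounds with values here, no measured step covers this swap, so the one known step gives only weak guidance. A moderate rise is expected, a 3.4-fold higher number from compound 2 to compound 3 (0.53 log units; beyond the scatter), giving compound 3 an estimated 5 nM, with a range from 1 nM to 25 nM.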

Compound 3, half-maximal inhibitory concentration: 17.4 nM
Compound 3: middle estimate off by 3.5-fold (0.54 log units), on the low side; the measured number falls inside the stated range.
By their numbers in this assay, from the lowest: compound 2; then compound 1; then compound 3.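

In this assay, cyclobutylamino on this aromatic carbon, which lies between two ring nitrogen atoms, gives a weaker binder than either tertiary amino group, with a 12-fold higher number from compound 2 to compound 3 (1.07 log units; beyond the scatter) and a 2.7-fold higher number from compound 1 to compound 3 (0.43 log units; beyond the scatter). Compound 3 is thus the weakest of the three, and its group carries 1 hydrogen-bond donor where the other two groups carry 0. No measurement at hand explains this rise.

Going by these compounds, whether the rise follows the nitrogen's hydrogen or the ring remains open; the two change together here. Propylamino or cyclobutyl(methyl)amino at this position could help separate them.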